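The compounds below may be only part of what the source reports. "The series", "measured", "known", "first", "only" and "open" are said of these compounds alone.

In an ADME assay on the whole organism (Rattus norvegicus) for pharmacokinetics, using cassette dosing, at a dose of 1 mg/kg by the oral route (on this read-out higher numbers stand for higher oral bioavailability and lower numbers for lower oral bioavailability), compound 1 (`CC(C)Oc1ccc(/N=c2\[nH]c(=O)n(C[C@@H](C)C(=O)O)c(=O)n2Cc2ccc(Cl)cc2)cc1Cl`) gives 108% and compound 2 (`CC(C)Oc1ccc(/N=c2\[nH]c(=O)n(C[C@@H](O)CO)c(=O)n2Cc2ccc(Cl)cc2)cc1Cl`) gives 63%, so compound 2 holds the lower of the two numbers. The next structure is compound 3 (`CC(C)Oc1ccc(/N=c2\[nH]c(=O)n(CC(C)(C)C(=O)O)c(=O)n2Cc2ccc(Cl)cc2)cc1Cl`), which differs from compound 2 as follows: 1-carboxy-1-methylethyl in place of 1,2-dihydroxyethyl on a saturated chain carbon bound to an aromatic nitrogen. In words, 1-carboxy-1-methylethyl stands in place of 1,2-dihydroxyethyl on a saturated chain carbon bound to an aromatic nitrogen.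

Within the data shown here, only one measured step bears on this change: a number 45 percentage points lower from compound 1 to compound 2 (beyond the scatter), a large drop on replacing 1-carboxyethyl with 1,2-dihydroxyethyl. Among the measured compounds shown here, compound 3 goes the opposite way, back to a carboxy group, but 1-carboxy-1-methylethyl is not the same group as 1-carboxyethyl, and no measurement yet shows how much that matters. A large rise, probably somewhat smaller than that drop, is therefore expected, and the estimated move is a number 32 percentage points higher from compound 2 to compound 3 (beyond the scatter). For compound 3 the estimate is 95%, with an expected range of 65% to 125%.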

Compound 3, oral bioavailability: 85.3%
Estimate against measurement, compound 3: 9.7 percentage points above; measured number inside the range.
By their numbers in this assay, from the lowest: compound 2; then compound 3; then compound 1.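

In this assay, putting a carboxy group back at this position gives a number 22.3 percentage points higher from compound 2 to compound 3 (beyond the scatter), so 1-carboxy-1-methylethyl stands above 1,2-dihydroxyethyl, as 1-carboxyethyl does. The carboxy group alone does not set the number, however: the two carboxy-bearing groups differ beyond the scatter, with a number 22.7 percentage points lower from compound 1 to compound 3 (beyond the scatter). No measured evidence explains either step.

Compound 1 carries a defined stereocentre in its side chain and compound 3 has an extra methyl group and no stereocentre there, so the effects of the methyl group and of the stereocentre cannot be separated, and the mirror-image form of compound 1 would be needed to begin doing so. Also open, going by these compounds, is how an amine or a primary amide would read at this position, or a carboxylic acid on a longer chain.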